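This account rests on a few compounds, and the source may have more. Where it says the series, first, only, none or still open, it means among the compounds named here.

Series notes. The shared core of compound 2 `Cc1cc(NC(=O)C2C(C)(C)C2(C)C)ccc1N1CCC(N2CCCC2C)C1` carries an amide; in an assay on CHO cells for displacement of a labelled ligand from histamine receptor H3 (Macaca mulatta) (a higher number here means a weaker inhibitor, a lower number a stronger inhibitor), compound 2 gives 65.5 nM. Among the three compounds measured so far compound 2 stands second highest: compound 1 `CC(=O)N1CCCC1C(=O)Nc1ccc(N2CCC(N3CCCC3C)C2)c(C)c1` gives 44.9 nM in this assay, and compound 3 `CC1CCCN1C1CCN(c2ccc(NC(=O)C3C(C)(C)C3(C)C)cc2)C1` gives 144 nM. The step of a 1.5-fold higher number from compound 1 to compound 2 (0.16 log units; within the scatter) is within the scatter, so compounds 1 and 2 cannot be told apart on this assay; the step of a 2.2-fold higher number from compound 2 to compound 3 (0.34 log units; beyond the scatter) is beyond it.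

Compound 4 `Cc1cc(NC(=O)C2CCOCC2)ccc1N1CCC(N2CCCC2C)C1` differs from compound 2 in one place: oxan-4-yl in place of 2,2,3,3-tetramethylcyclopropyl on a carbonyl carbon. Among the compounds with values here, of the measured steps only the one from compound 1 to compound 2 touches the same place, the group on the carbonyl carbon, and that step, a 1.5-fold higher number from compound 1 to compound 2 (0.16 log units; within the scatter), showed no effect beyond the scatter when one seven-heavy-atom group replaced another. The step from compound 2 to compound 3 concerns the aromatic methyl and does not bear on this change. With a single exchange at the carbonyl carbon having shown no shift, the step from compound 2 to compound 4 in this assay is expected to be small, a 1.2-fold higher number from compound 2 to compound 4 (0.09 log units; within the scatter), with a wide range allowed. Compound 4 is accordingly estimated at 80 nM in this assay, between 35 nM and 200 nM.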

Compound 4, inhibition constant: 17 nM
Compound 4: the middle estimate sits 4.7-fold (0.67 log units) above what was measured; measured number below the stated range.
By their numbers in this assay, from the lowest: compound 4; then compounds 1 and 2 (each within the scatter of the next); then compound 3.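

Within the data shown here, at the group on the carbonyl carbon, this assay does respond to the exchange: oxan-4-yl in place of 2,2,3,3-tetramethylcyclopropyl gives a 3.9-fold lower number from compound 2 to compound 4 (0.59 log units; beyond the scatter) and oxan-4-yl in place of 1-acetylpyrrolidin-2-yl gives a 2.6-fold lower number from compound 1 to compound 4 (0.42 log units; beyond the scatter) and both steps lie beyond the scatter, which the one earlier exchange at this place did not. Of the three groups now read on this carbonyl carbon with the aromatic methyl kept, oxan-4-yl therefore gives the lowest number, while the other two remain within the scatter of each other and cannot be ordered. No supporting data bear on why the number falls with this change.

As far as these compounds go, whether the ring oxygen of oxan-4-yl matters stays open, since a cyclohexyl group, its all-carbon counterpart, or a piperidin-4-yl group, with an amine in place of that oxygen, would be needed to separate the oxygen from the ring itself. Also open, from the compounds shown here alone, is whether oxan-4-yl gives a similar step on the core of compound 3, which lacks the aromatic methyl.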